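This account rests on a few compounds, and the source may have more. Where it says the series, first, only, none or still open, it means among the compounds named here.

Measured so far in an ADME assay on HaCaT cells (Homo sapiens) for cytotoxicity, read by MTT assay, with a stated time of 72 h; on this read-out higher numbers stand for weaker inhibition and lower numbers for stronger inhibition:
compound 1, `NS(=O)(=O)c1cc(-c2nnc(CN3CCN(c4ccc(F)cc4)CC3)o2)c(Cl)cc1SCc1ccccc1`, gives 110000 nM
compound 2, `NS(=O)(=O)c1cc(-c2nnc(Cn3cc(-c4ccccc4)nn3)o2)c(Cl)cc1SCc1ccccc1`, gives 300000 nM
compound 3, `NS(=O)(=O)c1cc(-c2nnc(/C=C/c3ccccc3)o2)c(Cl)cc1SCc1ccccc1`, gives 20000 nM

Compound 2 holds the highest number of the three in this assay, which on this read-out means the weakest toxicity toward these skin cells; compound 1 lies nearest to it and compound 3 furthest away, both beyond the usual scatter. The unmeasured compound 4, `NS(=O)(=O)c1cc(-c2nnc(/C=C/c3c(Cl)cccc3Cl)o2)c(Cl)cc1SCc1ccccc1`, differs from compound 2 in one place: 2-(2,6-dichlorophenyl)ethenyl in place of (4-phenyl-1H-1,2,3-triazol-1-yl)methyl on an aromatic carbon.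

Among the measured compounds shown here, only one measured step bears on this change, the one in which the same triazolylmethyl group gave way to a 2-phenylethenyl chain on the same ring carbon: a 15-fold lower number from compound 2 to compound 3 (1.18 log units; beyond the scatter). For the measured compounds named here, compound 4 carries the same ethenyl link, here to a 2-(2,6-dichlorophenyl)ethenyl group; no measured pair shows what the two chlorines add on their own, so the step from compound 2 to compound 3 is the only guide.

A step of about that size and direction is therefore expected, toward a lower number: a 20-fold lower number from compound 2 to compound 4 (1.30 log units; beyond the scatter). On this basis compound 4 is estimated at 15000 nM in this assay, expected to fall between 5000 nM and 50000 nM.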

Compound 4, half-maximal inhibitory concentration: 160000 nM
Estimate against measurement, compound 4: 11-fold (1.03 log units) below; the whole stated range lies below it.
By their numbers in this assay, from the lowest: compound 3; then compounds 1, 4 and 2 (each within the scatter of the next, the first and the last beyond it).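

In this assay, the ethenyl link does not by itself set the number at this ring carbon: replacing the triazole-bearing group with 2-(2,6-dichlorophenyl)ethenyl gives a 1.9-fold lower number from compound 2 to compound 4 (0.27 log units; within the scatter), so the two groups cannot be told apart here. The earlier compounds shown here could not separate the link from the ring at its end, but the two chlorines now do so, since 2,6-dichlorophenyl in place of phenyl gives an 8.0-fold higher number from compound 3 to compound 4 (0.90 log units; beyond the scatter), a change made on the ethenyl chain with everything else held the same. The low number of compound 3 therefore depends on what the ethenyl link carries as well as on the link itself, though nothing measured here accounts for the effect of the chlorines.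

Going by these compounds, it remains open whether a single chlorine on the phenyl ring would move the number as far as two do, or whether a methoxy group or a fluorine in place of the chlorines would do the same. Also open, on these data alone, is how a saturated 2-phenylethyl chain, which lacks the double bond, would compare with the 2-phenylethenyl chain.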